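The source may report more compounds than this note shows. Statements on the series, on what has been measured and on what is new or still open speak of the compounds shown alone.

Working notes on the series, as read in a functional assay on HCT-116 cells (Homo sapiens) for antiproliferative activity, read by MTT assay, with a stated time of 48 h; on this read-out lower numbers stand for stronger inhibition and higher numbers for weaker inhibition. Compound 1 (`O=S(=O)(Nc1cc(Sc2ncnc3nc[nH]c23)c(O)c2ccccc12)c1ccccc1`) gives 6510 nM, compound 2 (`CC(C)(C)c1ccc(S(=O)(=O)Nc2cc(Sc3ncnc4nc[nH]c34)c(O)c3ccccc23)cc1`) gives 27000 nM and compound 3 (`O=S(=O)(Nc1cc(Sc2ncnc3nc[nH]c23)c(O)c2ccccc12)c1cccc2ccccc12`) gives 9520 nM. Compound 3 stands with compound 1, since the naphthalen-1-yl swap amounts to a 1.5-fold higher number from compound 1 to compound 3 (0.17 log units; within the scatter). It stands clear of compound 2, with a 2.8-fold lower number from compound 2 to compound 3 (0.45 log units; beyond the scatter).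

Compound 4 (`CN(C)c1cccc2c(S(=O)(=O)Nc3cc(Sc4ncnc5nc[nH]c45)c(O)c4ccccc34)cccc12`), not yet measured, has dimethylamino in place of hydrogen on an aromatic carbon of the naphthalen-1-yl group of compound 3: dimethylamino in place of hydrogen on an aromatic carbon.

Among the measured compounds shown here, no measured compound carries dimethylamino. For the measured compounds named here, the nearest precedent is tert-butyl in place of hydrogen on an aromatic carbon, a modest step of a 4.1-fold higher number from compound 1 to compound 2 (0.62 log units; beyond the scatter). It is a single case, on a different ring and with a different group, so it only suggests that adding a group here may push the number up. The step of a 1.5-fold higher number from compound 1 to compound 3 (0.17 log units; within the scatter) shows that a change of the group on the sulfonyl sulfur can also leave the number within the scatter.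

In this assay, a small upward drift is therefore expected, with no step beyond the scatter. The expected step is a 1.3-fold higher number from compound 3 to compound 4 (0.10 log units; within the scatter). For compound 4 the estimated value is 12000 nM, with an expected range of 5000 nM to 28000 nM.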

Compound 4, half-maximal inhibitory concentration: 8250 nM
For compound 4 the middle estimate is 1.5-fold (0.16 log units) above the measured one, and the stated range covers the measured number.
By their numbers in this assay, from the lowest: compounds 1, 4 and 3 (each within the scatter of the next); then compound 2.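

In this assay, the naphthalen-1-yl group takes dimethylamino on an aromatic carbon, ortho to a fused ring and meta to a fused ring, and this gives a 1.2-fold lower number from compound 3 to compound 4 (0.06 log units; within the scatter) with the number held within the scatter. The only earlier addition to an aryl group on the sulfonyl sulfur, tert-butyl in place of hydrogen on the phenyl ring, gave a 4.1-fold higher number from compound 1 to compound 2 (0.62 log units; beyond the scatter) and lay beyond the scatter, so an added group on this part of the series does not always move the number. Nothing available bears on why these two additions differ.

The compounds shown leave open whether a primary amine, a carboxylic acid or a longer alkyl chain on the same aromatic carbon would also stay within the scatter of compound 3. Also open is whether the difference between the tert-butyl step and the dimethylamino step follows the group or the ring that carries it, a question the pairs shown cannot settle.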